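The source may hold more compounds than are shown below. What is called first, only, known or untested is meant among the compounds shown, and "the series" means these compounds.

In a functional assay on PC-3 cells (Homo sapiens) for antiproliferative activity, read by MTT assay, with a stated time of 48 h (on this read-out lower numbers stand for stronger inhibition and higher numbers for weaker inhibition), compound 1 `CCn1c(C(=O)Nc2ccc(OC(F)(F)F)cc2)ccc1C(CC)(CC)c1ccc(OCCC(O)(CC)CC)c(C)c1` gives > 50000 nM, which is a limit and not a number. Compound 2 `CCOC(=O)C(CC(=O)OC)NC(=O)c1ccc(C(CC)(CC)c2ccc(OCCC(O)(CC)CC)c(C)c2)n1CC` gives 5840 nM. Compound 3 `CCC(C)C(NC(=O)c1ccc(C(CC)(CC)c2ccc(OCCC(O)(CC)CC)c(C)c2)n1CC)C(=O)O` gives 13800 nM, the higher of the two true numbers. Compound 4 `CCC(C)C(CO)NC(=O)c1ccc(C(CC)(CC)c2ccc(OCCC(O)(CC)CC)c(C)c2)n1CC` is not yet measured. The change hydroxymethyl in place of carboxy on a saturated chain carbon bound to an amide-type nitrogen and a saturated chain carbon puts hydroxymethyl in place of carboxy on a saturated chain carbon bound to an amide-type nitrogen and a saturated chain carbon. The nearest evidence is a 2.4-fold higher number from compound 2 to compound 3 (0.37 log units; beyond the scatter), with an at least 3.6-fold lower number from compound 1 to compound 3 (0.55 log units; beyond the scatter) and an at least 8.5-fold lower number from compound 1 to compound 2 (0.93 log units; beyond the scatter) further off. All three alter the whole group on the amide-type nitrogen, and none isolates this swap. The modest size of a 2.4-fold higher number from compound 2 to compound 3 (0.37 log units; beyond the scatter) means no step beyond the scatter is expected in this assay. The expected step is a 1.3-fold lower number from compound 3 to compound 4 (0.10 log units; within the scatter). Compound 4 is estimated at 11000 nM, with an expected range of 4000 nM to 30000 nM.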

Compound 4, half-maximal inhibitory concentration: 28400 nM
The estimate for compound 4 lay 2.6-fold (0.41 log units) below the measured number, within the range that was stated.
By their numbers in this assay, from the lowest: compound 2; then compound 3; then compound 4. At a limit, above all of these: compound 1.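

In this assay, going by these compounds alone, hydroxymethyl in place of carboxy on a saturated chain carbon bound to an amide-type nitrogen and a saturated chain carbon gives the first reading that isolates this position, a 2.1-fold higher number from compound 3 to compound 4 (0.31 log units; beyond the scatter), a modest step that is beyond the scatter. Changing the whole group on the amide-type nitrogen gives a larger gap, a 4.9-fold higher number from compound 2 to compound 4 (0.69 log units; beyond the scatter), the widest among the true numbers in this set. Compound 1 stands at a limit: the limit of > 50000 nM in this assay, at which 1 of the 4 values shown sits. Against that limit the data give only an at least 1.7-fold lower number from compound 1 to compound 4 (0.24 log units; that floor lies within the scatter).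

Open, from the compounds shown here alone, is how an amine or a carboxamide on that carbon would read. Also open, going by these compounds, is whether the step keeps its direction with a longer chain there.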